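Aryl replacement at the fused core in a cytotoxicity assay

A few compounds are considered here, and "the series" means these few. Any claim that something is new, unique, unknown or untested is made for them only; others in the source may bear on it.

Three compounds have been measured in an ADME assay on HepG2 cells (Homo sapiens) for cytotoxicity, read by luminescence, CellTiter-Glo and ATP content, with a stated time of 72 h; on this read-out lower numbers stand for an effect already at smaller amounts and higher numbers for an effect only at larger amounts of compound:
compound 1 `COc1ccc(Oc2ccc3c(NCCCNCc4cc(F)ccc4OC)ccnc3c2)cc1` gives 7000 nM
compound 2 `COc1ccc(F)cc1CNCCCNc1ccnc2cc(CCc3ccccc3)ccc12` gives 4240 nM
compound 3 `COc1ccc(F)cc1CNCCCNc1ccnc2cc(-c3cccc4ccccc34)ccc12` gives 16000 nM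

Compound 3 stands at the highest number of the three; the nearest is compound 1 and the furthest compound 2, with both steps beyond the scatter. Compound 4 `COc1ccc(F)cc1CNCCCNc1ccnc2cc(-c3ccc(C(F)(F)F)cc3)ccc12` is not yet measured. 4-(trifluoromethyl)phenyl in place of naphthalen-1-yl on an aromatic carbon

Going by the values given here, two measured steps bear on this change, since both end at the naphthalen-1-yl compound: a 2.3-fold higher number from compound 1 to compound 3 (0.36 log units; beyond the scatter) and a 3.8-fold higher number from compound 2 to compound 3 (0.58 log units; beyond the scatter). Both replacements of a group by naphthalen-1-yl raised the number modestly. Among the compounds with values here, compound 4 carries one six-membered aromatic ring of carbon only in its place, and a modest step back down in this assay is therefore expected, toward the numbers of compound 1 and compound 2, though no measured pair shows 4-(trifluoromethyl)phenyl itself. For compound 4 the expected step is a 2.0-fold lower number from compound 3 to compound 4 (0.30 log units; within the scatter). The estimate for compound 4 in this assay is 8000 nM, with a range from 3500 nM to 18000 nM.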

Compound 4, half-maximal effective concentration: 5190 nM
Compound 4: the middle estimate sits 1.5-fold (0.19 log units) above what was measured, within the range that was stated.
By their numbers in this assay, from the lowest: compounds 2, 4 and 1 (each within the scatter of the next); then compound 3.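

In this assay the exchange of naphthalen-1-yl for 4-(trifluoromethyl)phenyl, with the same heavy-atom count on both sides, gives a 3.1-fold lower number from compound 3 to compound 4 (0.49 log units; beyond the scatter) and so shows that a ring set directly on this aromatic carbon does not by itself bring the high number of compound 3. The new compound also joins the earlier ones, with a 1.2-fold higher number from compound 2 to compound 4 (0.09 log units; within the scatter) and a 1.3-fold lower number from compound 1 to compound 4 (0.13 log units; within the scatter), both within the scatter, leaving compound 3 as the only one of the four set apart at this position. No measurement at hand offers a reason for this difference.

The compounds shown leave open whether the step follows the loss of the second ring or the arrival of the trifluoromethyl group, which a plain phenyl at this place could separate. Going by these compounds, how an amine or a carboxylic acid on this aromatic carbon would read in this assay also remains open.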